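From triazolyl diol to methylpiperazinyl chain

This account rests on a few compounds, and the source may have more. Where it says the series, first, only, none or still open, it means among the compounds named here.

In a toxicity assay on L02 cells (Homo sapiens) for cytotoxicity, read by MTT assay, with a stated time of 72 h (on this read-out lower numbers stand for stronger inhibition and higher numbers for weaker inhibition), compound 3 (`O=C1c2c[n+]([O-])c3ccccc3c2C(=O)c2c1c1ccccc1n2Cc1cn(CC(O)CO)nn1`) gives 1070 nM and sits at the upper end of the numbers in hand. Compound 2 (`O=C1c2c[n+]([O-])c3ccccc3c2C(=O)c2c1c1ccccc1n2Cc1cn(C[C@H](O)CO)nn1`) gives 1130 nM in the same region. The gap between them is a 1.1-fold lower number from compound 2 to compound 3 (0.02 log units; within the scatter) and the only difference is the fact that one of compounds 2 and 3 is drawn with a defined configuration and the other without, at the place where they differ at that carbon. Compound 1 (`O=C1c2c[n+]([O-])c3ccccc3c2C(=O)c2c1c1ccccc1n2CCCCn1ccnc1`) lies clearly lower at 150 nM on this read-out.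

Compound 4 (`CN1CCN(CCCCn2c3c(c4ccccc42)C(=O)c2c[n+]([O-])c4ccccc4c2C3=O)CC1`) carries 3-(4-methylpiperazin-1-yl)propyl in place of 1-(2,3-dihydroxypropyl)-1H-1,2,3-triazol-4-yl on a saturated chain carbon bound to an aromatic nitrogen.

Two measured steps involve the departing group at this place, each replacing 3-(1H-imidazol-1-yl)propyl: a 7.5-fold higher number from compound 1 to compound 2 (0.88 log units; beyond the scatter) and a 7.1-fold higher number from compound 1 to compound 3 (0.85 log units; beyond the scatter) on the same scale. Both lie beyond the scatter and lead to higher numbers. Compound 4 gives up the triazolyl group and takes a different 3-substituted propyl group, so a step of similar size towards lower numbers is expected in this assay by reversing a 7.1-fold higher number from compound 1 to compound 3 (0.85 log units; beyond the scatter) as the guide. Going by the values given here, only one such propyl group has been measured, so the expectation stays loose. The estimated change is a 4.9-fold lower number from compound 3 to compound 4 (0.69 log units; beyond the scatter) on this basis. The estimate for compound 4 is 220 nM with an expected range from 70 nM to 700 nM in this assay.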

Compound 4, half-maximal inhibitory concentration: 80 nM
The estimate for compound 4 lay 2.8-fold (0.44 log units) above the measured number, and the stated range covers the measured number.
By their numbers in this assay, from the lowest: compounds 4 and 1 (each within the scatter of the next); then compounds 3 and 2 (each within the scatter of the next).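

In this assay the move to 3-(4-methylpiperazin-1-yl)propyl on a saturated chain carbon bound to an aromatic nitrogen gives a 13-fold lower number from compound 3 to compound 4 (1.13 log units; beyond the scatter) and a 14-fold lower number from compound 2 to compound 4 (1.15 log units; beyond the scatter) as well, and both are large steps running opposite to those from the imidazolyl compound to the two triazolyl diols. The new information is a second end group on the butyl chain: with a 1.9-fold lower number from compound 1 to compound 4 (0.27 log units; within the scatter) in this assay the 1H-imidazol-1-yl and 4-methylpiperazin-1-yl groups are not separated on this read-out, something a single compound of this kind could not show. Across these four compounds, the two with a ring at the end of a butyl chain stand apart from the two triazolyl diols, and none goes against this.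

As far as these compounds go, whether this separation belongs to the butyl chain or to the ring at its end stays open; a morpholin-4-yl or dimethylamino group on the same chain, or 4-methylpiperazin-1-yl on a longer chain, would help to separate the two. Nothing recorded for this series bears on what lies behind the change at this position.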